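The source may report more compounds than this note shows. Statements on the series, on what has been measured and on what is new or still open speak of the compounds shown alone.

Measured so far in an ADME assay on HCT-116 cells (Homo sapiens) for cytotoxicity, read by CellTiter-Glo, with a stated time of 72 h; a higher number here means a weaker inhibitor, a lower number a stronger inhibitor:

compound 1 `CC1CCN(C2CCN(S(=O)(=O)c3cccc(-c4ccccc4F)c3)CC2)CC1`: for compound 1 the result is a limit of the assay, > 5000 nM.
compound 2 `CC1CCN(C2CCN(S(=O)(=O)c3cccc(-c4ccc(F)cc4)c3)CC2)CC1`: for compound 2 the result is a limit of the assay, > 5000 nM.
compound 3 `CC1CCN(C2CCN(S(=O)(=O)c3cccc4cnccc34)CC2)CC1`: for compound 3 the result is a limit of the assay, > 10000 nM.

Compound 2 therefore stands at a limit in this assay and no number is known for it; the other two values shown are likewise limits, two of the three sitting at the limit of > 5000 nM in this assay, at which 2 of the 3 values shown sit, and one at the limit of > 10000 nM in this assay, at which 1 of the 3 values shown sits. For the measured compounds named here, the only step between measured compounds that differ in one place, a step that the two limits leave unreadable from compound 1 to compound 2, cannot be given a size. Nothing in the set yields a readable change for any exchange of the aromatic group at this place.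

Compound 4 `CC1CCN(C2CCN(S(=O)(=O)c3cccc(-c4ccc5ccccc5c4)c3)CC2)CC1` differs from compound 2 by naphthalen-2-yl in place of 4-fluorophenyl on an aromatic carbon. Going by the values given here, no measured step bears on this change with a usable size, so no direction can be read from the data; what the three limits do show is that the whole series, across the three aromatic groups tried, stays outside the range where a number is reported. On that basis the step from compound 2 to compound 4, a step that the limit leaves unreadable from compound 2 to compound 4, is expected to be nothing beyond the scatter. Compound 4 is accordingly estimated at 8000 nM, within 3000 nM to 30000 nM, most likely reported again as a limit.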

Compound 4, half-maximal inhibitory concentration: > 5000 nM
Compound 4: a limit, no number; the forecaster's own chance of this, stated with the estimate: 70%; the middle value lies beyond the limit too.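

In this assay compound 4 gives > 5000 nM, a limit of the assay and not a number. The steps to compound 4 from compound 1 and from compound 2 therefore cannot be read. The compounds shown leave open whether any aromatic group at this place gives a reported number in this assay.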